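A few compounds are considered here, and "the series" means these few. Any claim that something is new, unique, unknown or untested is made for them only; others in the source may bear on it.

Of the compounds shown here, three have so far been measured in an assay for inhibition of Tryptophan 2,3-dioxygenase (Homo sapiens), with stated times of 10 min and 60 min, tested at 100 uM; a lower number here means a weaker effect, a higher number a stronger effect of the compound at the concentration tested. Compound 1 `CC(C)n1ncc2c(NCc3ccccc3[N+](=O)[O-])cc(C(F)(F)F)cc21` gives 32%. Compound 3 `O=[N+]([O-])c1ccc(CNc2cc(Br)cc3[nH]ncc23)cc1` gives 93%. Compound 2 `FC(F)(F)c1cc(NC[C@H]2CCCCN2)c2cn[nH]c2c1` gives 90%, the second highest of the three numbers; its nearest neighbour is compound 3, whose number lies within the scatter of it, while compound 1 stands far lower, beyond the scatter. Compound 4 `FC(F)(F)c1cc(NC[C@@H]2CCCCN2)c2cn[nH]c2c1` has not yet been measured. It differs from compound 2 as follows: the two compounds have the same atoms and bonds and differ only in configuration as drawn: 1 of 1 stereo elements differ; a stereocentre at a saturated ring carbon is drawn R in compound 2 and S in compound 4. Going by the values given here, no step between measured compounds bears on such a change, so its size is uncertain here. A fall, possibly beyond the scatter, is considered plausible, with the expected step being a number 20 percentage points lower from compound 2 to compound 4 (beyond the scatter). Compound 4 is estimated to give 70%, in a range from 35% to 95%.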

Compound 4, a percentage reported as inhibition, at one concentration (the size of the read-out at that concentration, not a potency): 88%
Compound 4: middle estimate off by 18 percentage points, on the low side, within the range that was stated.
By their numbers in this assay, from the lowest: compound 1; then compounds 4, 2 and 3 (each within the scatter of the next).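

Inverting the stereocentre at the saturated ring carbon appears in this assay as a number 2 percentage points lower from compound 2 to compound 4 (within the scatter), so at the concentration tested the drawn configuration at this position makes no difference that can be told from the scatter. None of the earlier compounds bore on this position, and this step can be assigned to that stereocentre alone: the fact that compounds 2 and 4 differ only in the configuration as drawn

As far as these compounds go, it remains open whether the two configurations would also stay level in a measure of potency rather than at a single concentration. From the compounds shown here alone, the effect of a carboxylic acid or a longer chain in place of the saturated ring also remains open.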